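The source may hold more compounds than are shown below. What is called first, only, known or untested is meant among the compounds shown, and "the series" means these compounds.

Compound 1 `Clc1ccc(Cn2c(Cl)nc3cc(Cl)c(Cl)cc32)cc1`: in a functional assay on KB cells (Homo sapiens) for inhibition (on this read-out lower numbers stand for stronger inhibition and higher numbers for weaker inhibition), compound 1 gives > 100000 nM, which is a limit of the assay rather than a number.
Compound 2 `COc1ccc(Cn2c(Cl)nc3cc(Cl)c(Cl)cc32)cc1`: in this assay compound 2 gives > 100000 nM, again only a limit.
Compound 3 `Clc1ccc(Cn2c(Br)nc3cc(Cl)c(Cl)cc32)cc1`: in this assay compound 3 gives > 100000 nM, also a limit.

Compound 2 differs from compound 1 by a single change, (methoxy in place of chloro on an aromatic carbon). Because every value sits at the limit of > 100000 nM in this assay, at which 3 of the 3 values shown sit, the step that the two limits leave unreadable from compound 1 to compound 2 cannot be sized. Compound 3 has a different core from compound 1, (bromo in place of chloro on an aromatic carbon). The step that the two limits leave unreadable from compound 1 to compound 3 is unreadable for the same reason.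

Compound 4 `COc1ccc(Cn2c(Br)nc3cc(Cl)c(Cl)cc32)cc1` has not yet been measured. It differs from compound 3 by methoxy in place of chloro on an aromatic carbon, the same change that turns compound 1 into compound 2, here made on the core of compound 3. Since compound 3 sits at the limit of > 100000 nM in this assay, at which 3 of the 3 values shown sit, and the same change left compound 2 at that limit, compound 4 is expected to remain at the limit as well, so the step that the limit leaves unreadable from compound 3 to compound 4 is an estimate rather than a reading. For compound 4 a value of about 300000 nM is expected, most likely reported only as a limit once more.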

Compound 4, half-maximal inhibitory concentration: 55000 nM
The estimate for compound 4 lay 5.5-fold (0.74 log units) above the measured number, outside the stated range (below it).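

In this assay, methoxy in place of chloro on an aromatic carbon, made on the core of compound 3, gives an at least 1.8-fold lower number from compound 3 to compound 4 (0.25 log units; that floor lies within the scatter), and bromo in place of chloro on an aromatic carbon, made with the methoxy group in place, gives an at least 1.8-fold lower number from compound 2 to compound 4 (0.25 log units; that floor lies within the scatter). As far as these compounds go, the same methoxy change on the core of compound 1 cannot be sized, and neither can the bromo change made with the chloro group in place, because each of those pairs has only limits to compare: the limit of > 100000 nM in this assay, at which 3 of the 4 values shown sit. So the series shows one measurable number, for compound 4, but it does not show that the methoxy change carries from one core to the other, nor that it fails to, and the true size of both new steps remains unknown.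

The compounds shown leave open how an amine or a carboxylic acid in place of the methoxy group would read in this assay. They also leave open whether a longer chain, such as ethoxy, would give a value that can be separated from the limit.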